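The compounds below may be only part of what the source reports. "The series", "measured", "known", "first", "only" and "open" are said of these compounds alone.

In a functional assay on ACHN cells (Homo sapiens) for antiproliferative activity, read by sulforhodamine B assay (on this read-out higher numbers stand for weaker inhibition of growth and lower numbers for stronger inhibition of growth), compound 1 `CCCCCCOc1cccc(O)c1C(=O)/C=C/c1ccc(O)cc1` reaches only a limit of the assay, > 30000 nM. Compound 2 `O=C(/C=C/c1ccc(O)cc1)c1c(O)cccc1OCC1CCCC1` gives 3510 nM and compound 3 `CCC(CC)COc1cccc(O)c1C(=O)/C=C/c1ccc(O)cc1` gives 3370 nM, so compound 3 stands level with compound 2: a 1.0-fold lower number from compound 2 to compound 3 (0.02 log units; within the scatter). Compound 4 `CC(C)COc1cccc(O)c1C(=O)/C=C/c1ccc(O)cc1` carries isopropyl in place of pentan-3-yl on a saturated chain carbon bound to an oxygen on an aromatic ring. Two measured steps, an at least 8.5-fold lower number from compound 1 to compound 2 (0.93 log units; beyond the scatter) and an at least 8.9-fold lower number from compound 1 to compound 3 (0.94 log units; beyond the scatter), show how much this chain position can matter, though neither is this same exchange. The closest guide is a 1.0-fold lower number from compound 2 to compound 3 (0.02 log units; within the scatter), which changed nothing beyond the scatter. The estimated step in this assay, a 1.5-fold higher number from compound 3 to compound 4 (0.17 log units; within the scatter), therefore leans towards a higher number but is expected to stay small. Compound 4 is expected at 5000 nM, within an estimated range of 2000 nM to 15000 nM.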

Compound 4, concentration for 50% growth inhibition: 3290 nM
The estimate for compound 4 lay 1.5-fold (0.18 log units) above the measured number; measured number inside the range.
By their numbers in this assay, from the lowest: compounds 4, 3 and 2 (each within the scatter of the next). At a limit, above all of these: compound 1.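

In this assay the smaller isopropyl reads level with pentan-3-yl (a 1.0-fold lower number from compound 3 to compound 4 (0.01 log units; within the scatter)) and with cyclopentyl (a 1.1-fold lower number from compound 2 to compound 4 (0.03 log units; within the scatter)), so this saturated chain carbon now carries three different groups with no change beyond the scatter. Only the pentyl of compound 1 stands apart (an at least 9.1-fold lower number from compound 1 to compound 4 (0.95 log units; beyond the scatter)). Compound 1 gives a limit, not a number: the limit of > 30000 nM in this assay, at which 1 of the 4 values shown sits. The compounds shown leave open whether a longer branched chain or a straight chain shorter than pentyl would read like compound 4 or like compound 1. They also leave open how an amine or a carboxylic acid at the end of this chain would read.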